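Chloro for Trifluoromethyl: an Untested Analogue

A few compounds are considered here, and "the series" means these few. Any claim that something is new, unique, unknown or untested is made for them only; others in the source may bear on it.

Compound 1 `O=C(Nc1ccc2c(c1)B(O)OC2)c1ccccc1C(F)(F)F` gives 4400 nM in a functional assay on PBMC cells (Homo sapiens) for inhibition, read by HTRF, with stated times of 15 min and 24 h; on this read-out lower numbers stand for stronger inhibition and higher numbers for weaker inhibition.
Compound 2 `O=C(Nc1ccc2c(c1)B(O)OC2)c1ccccc1Cl` gives > 100000 nM in this assay, which is a limit of the measurement rather than a number.
Compound 3 `O=C(Nc1ccc2c(c1)B(O)OC2)c1cccc(C(F)(F)F)c1F` gives > 100000 nM in this assay, again a limit rather than a number.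

Compounds 1 and 2 share a core and differ in one place: chloro in place of trifluoromethyl on an aromatic carbon. That change produced an at least 22-fold higher number from compound 1 to compound 2 (1.35 log units; beyond the scatter). Compound 3 has a different core from compound 1, and the difference between the two cores is not broken down here.

Compound 4 `O=C(Nc1ccc2c(c1)B(O)OC2)c1cccc(Cl)c1F` has not yet been measured. It differs from compound 3 by the same kind of change, (chloro in place of trifluoromethyl on an aromatic carbon), but the surroundings are not identical: in compound 1 the site is ortho to a large group, whereas in compound 3 it is ortho to a fluoro group (1 heavy atom) and meta to a large group.

For compound 4 the expected step is a step that the limit leaves unreadable from compound 3 to compound 4. This expectation rests on compound 3 already sitting at the limit of > 100000 nM in this assay, at which 2 of the 3 values shown sit, together with an at least 22-fold higher number from compound 1 to compound 2 (1.35 log units; beyond the scatter). Compound 4 is therefore estimated at 300000 nM, most likely between 100000 nM and 1000000 nM.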

Compound 4, half-maximal inhibitory concentration: > 100000 nM
Compound 4 gave a limit, no number; the forecaster's own chance of this, stated with the estimate: 90%; the middle value is on the limit's open side.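

Compound 3 and compound 4 both stop at a limit rather than a number in this assay, so no step can be read between them: the limit of > 100000 nM in this assay, at which 3 of the 4 values shown sit.

The compounds shown leave open whether chloro in place of trifluoromethyl, at this place ortho to a fluoro group, changes the inhibition at all, and in which direction.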